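The source may hold more compounds than are shown below. What is called first, only, known or untested is meant among the compounds shown, and "the series" means these compounds.

Values measured in a functional assay on B16 cells (Mus musculus) for inhibition; a higher number here means a weaker inhibitor, a lower number a stronger inhibitor:

- compound 1 `CC(C)(C)c1ccccc1NC(N)=S`: > 10000 nM
- compound 2 `NC(=S)NCc1ccccc1`: > 10000 nM
- compound 3 `Cc1ccc(/C=N/NC(N)=S)cc1`: 6800 nM

Compound 1 is reported only as a limit of the assay, > 10000 nM. Compound 2 is likewise reported only as a limit, > 10000 nM. Compound 3, at 6800 nM, is the only one of the three with an actual number in this assay.

Compound 4 `CC(C)(C)c1ccc(/C=N/NC(N)=S)cc1` keeps the core of compound 3 and alters one group: tert-butyl in place of methyl on an aromatic carbon. This places tert-butyl in place of methyl on an aromatic carbon, para to a group of 6 heavy atoms.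

Going by the values given here, no measured pair shows this change, so its size cannot be read from the data. The expectation therefore starts from compound 3 at 6800 nM, and no step beyond the scatter is expected in this assay. The expected change is a 1.4-fold lower number from compound 3 to compound 4 (0.13 log units; within the scatter). Compound 4 is estimated at 5000 nM, with an expected range from 1500 nM to 10000 nM.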

Compound 4, half-maximal inhibitory concentration: 2700 nM
Beside the measured number, compound 4's estimate is 1.9-fold (0.27 log units) above it; the measured number falls inside the stated range.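

In this assay, tert-butyl in place of methyl on an aromatic carbon, para to a group of 6 heavy atoms, gives a 2.5-fold lower number from compound 3 to compound 4 (0.40 log units; beyond the scatter). Going by these compounds alone, this is the first step that can be read at this place, and it shows that 4 heavy atoms can stand where 1 stood with no loss of inhibition in this assay; here the bigger of the two groups carries the lower number. The finding rests on this single pair, and the other values offer no number to set beside it: the limit of > 10000 nM in this assay, at which 2 of the 4 values shown sit.

As far as these compounds go, whether the number keeps falling through ethyl or isopropyl, or what a methoxy group or an amine would do at the same place, stays open. Also open, from the compounds shown here alone, is whether the same change would give a step of similar size on another core.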